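Extending the chain by one more carbon in compound 3

A few compounds are considered here, and "the series" means these few. Any claim that something is new, unique, unknown or untested is made for them only; others in the source may bear on it.

Compound 1, `N#C/N=C1\N(CCCCCOc2ccc(Cl)cc2)C(=O)CN1c1ccncc1`, gives 3800 nM in a functional assay on DLD-1 cells (Homo sapiens) for cytotoxicity; a lower number here means a stronger inhibitor, a higher number a weaker inhibitor.
Compound 2, `N#C/N=C1\N(CCCCCCOc2ccc(Cl)cc2)C(=O)CN1c1ccncc1`, gives 3440 nM in this assay.

On the two numbers shown, compound 2 cannot be told apart from compound 1, since the step of a 1.1-fold lower number from compound 1 to compound 2 (0.04 log units; within the scatter) lies within the scatter. Compound 3, `N#C/N=C1\N(CCCCCCCOc2ccc(Cl)cc2)C(=O)CN1c1ccncc1`, differs from compound 2 in one place: (4-chlorophenoxy)methyl in place of 4-chlorophenoxy on a saturated chain carbon, six bonds along the chain from an amide-type nitrogen in a ring. Among the measured compounds shown here, the only measured step that bears on this change is a 1.1-fold lower number from compound 1 to compound 2 (0.04 log units; within the scatter), which is the same kind of change made at a saturated chain carbon five bonds along the chain from the amide-type nitrogen in the ring rather than six. That step did not move the number beyond the scatter, so no step beyond the scatter is expected here either, in this assay the step of a 1.0-fold lower number from compound 2 to compound 3 (0.01 log units; within the scatter) being the expectation. Compound 3 is therefore estimated at 3400 nM, with a range from 1700 nM to 7000 nM.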

Compound 3, half-maximal inhibitory concentration: 3340 nM
Compound 3: middle estimate off by 1.0-fold (0.01 log units), on the high side, and the stated range covers the measured number.
By their numbers in this assay, from the lowest: compounds 3, 2 and 1 (each within the scatter of the next).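

In this assay lengthening the chain once more again gives no readable change: the step of a 1.0-fold lower number from compound 2 to compound 3 (0.01 log units; within the scatter) lies within the scatter, so (4-chlorophenoxy)methyl in place of 4-chlorophenoxy has now been tried at two places along the chain with the same outcome. Across both extensions together, the step of a 1.1-fold lower number from compound 1 to compound 3 (0.06 log units; within the scatter), which puts 2-(4-chlorophenoxy)ethyl in place of 4-chlorophenoxy, also stays within the scatter, so the small differences do not build into a trend across these three compounds. No measurement available here accounts for this flat result.

Still open, as far as these compounds go, is whether a much longer chain, or a chain ending in an amine or a carboxylic acid instead of the 4-chlorophenoxy group, would move the number beyond the scatter. Also open, from the compounds shown here alone, is what a change to the shared core would do, as all three compounds carry it unchanged.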